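From furan-2-yl to 3-hydroxyphenyl: a step without precedent

The source may hold more compounds than are shown below. What is called first, only, known or untested is meant among the compounds shown, and "the series" means these compounds.

Of the compounds shown here, three have been measured in an assay on isolated protein for inhibition of Amine oxidase [flavin-containing] A (Homo sapiens), read by fluorescence; a higher number here means a weaker inhibitor, a lower number a stronger inhibitor. Compound 1 `O=C(/C=C/c1ccsc1)c1cc(O)c(O)c([N+](=O)[O-])c1` gives 41400 nM in this assay, and compound 2 `O=C(/C=C/c1nccs1)c1cc(O)c(O)c([N+](=O)[O-])c1` gives 69600 nM. For the measured compounds named here, the step of a 1.7-fold higher number from compound 1 to compound 2 (0.23 log units; within the scatter) is the only single-point change among the measured pairs. Compound 3 `CC(=O)N1N=C(c2cc(O)c(O)c([N+](=O)[O-])c2)CC1c1ccco1` has a core that differs from that of compound 1 and compound 2. In this assay compound 3 gives 98000 nM; its number is the highest of the three, though the gap to compound 2 is within the scatter and only the gap to compound 1 lies beyond it.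

Compound 4 `CC(=O)N1N=C(c2cc(O)c(O)c([N+](=O)[O-])c2)CC1c1cccc(O)c1` differs from compound 3 in one place: 3-hydroxyphenyl in place of furan-2-yl on a saturated ring carbon. Going by the values given here, no measured pair bears on this change directly. Among the compounds with values here, the one measured step, a 1.7-fold higher number from compound 1 to compound 2 (0.23 log units; within the scatter), concerns a different position on a different core and was itself within the scatter, so it offers no guide to direction or size. With nothing in the data arguing for a move either way, compound 4 is expected to sit close to compound 3. For compound 4, then, the expected step of a 1.2-fold lower number from compound 3 to compound 4 (0.06 log units; within the scatter) is one that stays within the scatter. Compound 4 is estimated at 85000 nM in this assay, with a range from 30000 nM to 240000 nM.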

Compound 4, half-maximal inhibitory concentration: 87000 nM
Beside the measured number, compound 4's estimate is 1.0-fold (0.01 log units) below it; low and high end bracket the measured number.
By their numbers in this assay, from the lowest: compounds 1, 2, 4 and 3 (each within the scatter of the next, the first and the last beyond it).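

For the compounds shown here, this is the first step read at the saturated ring carbon next to the ring nitrogen, and in this assay putting 3-hydroxyphenyl in place of furan-2-yl gives a 1.1-fold lower number from compound 3 to compound 4 (0.05 log units; within the scatter) so the two groups cannot be told apart by this number. Going by these compounds alone, the exchange is not a small one on paper: a six-membered aromatic ring of carbon only replaces a five-membered aromatic ring with 1 hetero atom, and 1 hydrogen-bond donor enters, yet on this core the whole change stays within the scatter, which the single earlier step, on a different core, could not show. Nothing in the available evidence explains this result.

On these data alone, what remains open is whether the ring and the hydroxyl each leave the number unmoved or merely offset one another, a question that plain phenyl at this carbon would address. Nor do these compounds show whether any group here can produce a step beyond the scatter, whether an amine, a carboxylic acid or a longer chain on this saturated ring carbon, or a change to the acetyl group on the ring nitrogen.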